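A few compounds are considered here, and "the series" means these few. Any claim that something is new, unique, unknown or untested is made for them only; others in the source may bear on it.

Three compounds share one core and differ only in the group carried on an amine nitrogen. In a functional assay on LNCaP cells (Homo sapiens) for antiproliferative activity, read by CCK-8 assay, with a stated time of 6 days (a lower number here means a stronger inhibitor, a higher number a weaker inhibitor), compound 1 `C[C@@H](Cn1ccc(-c2ccc(C#N)c(Cl)c2)n1)NC(=O)c1ccccc1F` gives 1810 nM. Compound 2 `C[C@@H](Cn1ccc(-c2ccc(C#N)c(Cl)c2)n1)Nc1ccncc1` gives 2560 nM in this assay, and compound 3 `C[C@@H](Cn1ccc(-c2ccc(C#N)c(Cl)c2)n1)Nc1nccc(Cl)n1` gives 1400 nM. The steps between them are all small: a 1.4-fold higher number from compound 1 to compound 2 (0.15 log units; within the scatter), a 1.3-fold lower number from compound 1 to compound 3 (0.11 log units; within the scatter) and a 1.8-fold lower number from compound 2 to compound 3 (0.26 log units; within the scatter). Compound 3 thus holds the lowest of the three numbers, but its distance to compound 1 and to compound 2 stays within the scatter, so the three cannot be told apart with confidence.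

Compound 4 `C[C@@H](Cn1ccc(-c2ccc(C#N)c(Cl)c2)n1)Nc1ncnc2nc[nH]c12` is not yet measured. It differs from compound 3 in one place: a group of 9 heavy atoms (5 carbon, 4 nitrogen; one five-membered aromatic ring with 2 hetero atoms, one six-membered aromatic ring with 2 hetero atoms) in place of a group of 7 heavy atoms (4 carbon, 2 nitrogen, 1 chlorine; one six-membered aromatic ring with 2 hetero atoms), on an amine nitrogen. Within the data shown here, the steps that bear on this are the ones that also exchange the group on that nitrogen, from compound 2 to compound 3 and from compound 1 to compound 3, and both stayed within the scatter. Three rather different groups on this nitrogen gave close numbers, so the new group is expected to change little; the expected step in this assay is a 1.1-fold higher number from compound 3 to compound 4 (0.06 log units; within the scatter), with no clear direction beyond the scatter. For compound 4 the estimate in this assay is 1600 nM, with a range from 500 nM to 5000 nM.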

Compound 4, half-maximal inhibitory concentration: 960 nM
Compound 4: middle estimate off by 1.7-fold (0.22 log units), on the high side, within the range that was stated.
By their numbers in this assay, from the lowest: compounds 4, 3, 1 and 2 (each within the scatter of the next, the first and the last beyond it).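

A larger group with one five-membered and one six-membered aromatic ring is accepted on the amine nitrogen in this assay, with a 1.5-fold lower number from compound 3 to compound 4 (0.16 log units; within the scatter) and a 1.9-fold lower number from compound 1 to compound 4 (0.28 log units; within the scatter), so this change from a single ring, or from a carbonyl-linked ring, cannot be told apart from repeat-measurement noise. Against the pyridin-4-yl group, however, the same group gives a 2.7-fold lower number from compound 2 to compound 4 (0.43 log units; beyond the scatter), a modest step and the only one at this position so far that lies beyond the scatter, which shows that the group on this nitrogen can shift the number measurably, if not by much. No measurement shown accounts for this step.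

The compounds leave open whether the hydrogen-bond donor counted in the group of compound 4 plays any part, and a methyl group in place of that ring hydrogen would address this. Also open, on these data alone, is how far the number can move with quite different groups on the amine nitrogen, such as a short alkyl chain, an acetyl group or a chain ending in a carboxylic acid.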